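Swapping oxolan-3-yl for 4,4-difluorocyclohexyl

The compounds below may be only part of what the source reports. "The series", "measured", "known", "first", "only" and "open" are said of these compounds alone.

In a physicochemical assay for solubility, using the shake flask method, measured as kinetic solubility, with a stated time of 20 h, at pH 2 (on this read-out higher numbers stand for higher solubility and lower numbers for lower solubility), compound 3 `FC(F)(F)c1ccc(Nc2cc3[nH]c(C4CCOC4)nc3cn2)nc1` gives 200000 nM. Compound 1 `Fc1ccc(-c2nc3cnc(Nc4ccccn4)cc3[nH]2)cc1F` gives 125000 nM, which lies within the usual scatter of the value for compound 3. Compound 2 `FC(F)(F)c1ccc(Nc2cc3[nH]c(-c4cccc(C(F)(F)F)c4)nc3cn2)nc1` reports only a limit, < 5000 nM. Compound 4 `FC1(F)CCC(c2nc3cnc(Nc4ccc(C(F)(F)F)cn4)cc3[nH]2)CC1` carries 4,4-difluorocyclohexyl in place of oxolan-3-yl on an aromatic carbon. Among the compounds with values here, the one measured step at this place, an at least 40-fold higher number from compound 2 to compound 3 (1.60 log units; beyond the scatter), is large and beyond the scatter, and it exchanged 3-(trifluoromethyl)phenyl for oxolan-3-yl. Compound 4 keeps a non-aromatic ring but loses the oxygen, so a moderate step towards a lower number is expected, smaller than that measured one. The expected change is a 5.0-fold lower number from compound 3 to compound 4 (0.70 log units; beyond the scatter). Compound 4 is estimated at 40000 nM, with an expected range of 8000 nM to 150000 nM.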

Compound 4, solubility: 199000 nM
Compound 4: the middle estimate sits 5.0-fold (0.70 log units) below what was measured; the measured number lies above the stated range.
By their numbers in this assay, from the lowest: compounds 1, 4 and 3 (each within the scatter of the next). At a limit, below all of these: compound 2.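

In this assay, the position on the aromatic carbon does not separate oxolan-3-yl from 4,4-difluorocyclohexyl, although one ring has a hetero atom and the other is carbon only: a 1.0-fold lower number from compound 3 to compound 4 (0.00 log units; within the scatter). With the ring oxygen gone, the large rise seen on leaving 3-(trifluoromethyl)phenyl remains: an at least 39-fold higher number from compound 2 to compound 4 (1.59 log units; beyond the scatter). Compound 2 stands at a limit, not a number: the limit of < 5000 nM in this assay, at which 1 of the 4 values shown sits.

Still open, going by these compounds, is whether an open-chain group at this carbon, such as a longer alkyl chain, or a ring bearing an amine would give similar numbers.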